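A few compounds are considered here, and "the series" means these few. Any claim that something is new, unique, unknown or untested is made for them only; others in the source may bear on it.

Compound 1 `CCOC(=O)[C@H](CCC(=O)O)NC(=O)c1ccc(Sc2nc3cc(N)cc(N)c3nc2-c2ccccc2)cc1`: in a functional assay on SNB-19 cells (Homo sapiens) for inhibition, read by sulforhodamine B assay, with a stated time of 48 h (a lower number here means that less compound is tolerated, a higher number that more compound is tolerated), compound 1 gives < 100000 nM, which is a limit of the assay.
Compound 2 `Nc1cc(N)c2nc(-c3ccccc3)c(Sc3ccc(F)cc3)nc2c1`: in this assay compound 2 gives 87100 nM.
Compound 3 `COc1cc(CNc2nc3cc(N)cc(N)c3nc2-c2ccccc2)cc(OC)c1OC`: in this assay compound 3 gives < 50200 nM, which is a limit of the assay.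

Of the three measured compounds, compound 2 is the only one for which this assay returns an actual number; the other two results are limits, as the limit of < 100000 nM in this assay, at which 1 of the 3 values shown sits, and the limit of < 50200 nM in this assay, at which 1 of the 3 values shown sits, record. Compound 2 stands alone as the single numerical anchor of this set. The other two values are limits. Among the compounds with values here, no step between two measured compounds can be computed from what has been measured.

Compound 4 `Nc1cc(N)c2nc(-c3ccccc3)c(Sc3ccc(Cl)c(Cl)c3)nc2c1` has not yet been tested in this assay. It differs from compound 2 in one place: 3,4-dichlorophenyl in place of 4-fluorophenyl on a sulfur. Nothing in the measured data shows how such a change acts on these cells, so any expectation rests on compound 2 alone. The expected step, a 1.5-fold lower number from compound 2 to compound 4 (0.16 log units; within the scatter), is small and is not expected to go clearly beyond the usual scatter in either direction. Compound 4 is accordingly estimated at 60000 nM, with a range from 20000 nM to 150000 nM.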

Compound 4, concentration lethal to 50% of the cells: < 100000 nM
Compound 4: only a limit was reported; the forecaster's own chance of this, stated with the estimate: 30%; the middle value lies beyond the limit too.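

In this assay compound 4 gives < 100000 nM, which is a limit of the assay. No step from compound 2 to compound 4 can be read, because that result is not a number: the limit of < 100000 nM in this assay, at which 2 of the 4 values shown sit.

The compounds shown leave open how 3,4-dichlorophenyl in place of 4-fluorophenyl on a sulfur acts on these cells, in size or in direction.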